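The source may report more compounds than this note shows. Statements on the series, on what has been measured and on what is new or still open speak of the compounds shown alone.

Measured compounds:
- compound 1 `O=C(Nc1cccc(-n2cc(-c3ccncc3)c(-c3cc(O)cc(Cl)c3)n2)c1)Nc1ccc(Cl)c(C(F)(F)F)c1`: -45%
- compound 2 `O=C(Nc1cccc(-n2cc(-c3ccncc3)c(-c3cc(O)cc(Cl)c3)n2)c1)Nc1ccc(Cl)c(Cl)c1`: -32%

Both were run in a functional assay on A549 cells (Homo sapiens) for inhibition, read by sulforhodamine B assay, with a stated time of 48 h, tested at 100 uM; on this read-out higher numbers stand for a weaker effect at the one concentration tested and lower numbers for a stronger effect. Compound 1 gives -45%, the lower of the two numbers; compound 2 gives -32%. For the measured compounds named here, the single measured step, a number 13 percentage points higher from compound 1 to compound 2 (beyond the scatter), concerns chloro in place of trifluoromethyl on an aromatic carbon, a different place from the one changed here.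

Compound 3 `COc1cc(Cl)cc(-c2nn(-c3cccc(NC(=O)Nc4ccc(Cl)c(C(F)(F)F)c4)c3)cc2-c2ccncc2)c1` differs from compound 1 by methyl in place of hydrogen on an oxygen on an aromatic ring. Going by the values given here, no measured step bears on this change, so the series gives no direction for it; a step within the usual scatter is expected, a number 7 percentage points higher from compound 1 to compound 3 (within the scatter). For compound 3 the estimate is -38%, with a range from -65% to -10%.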

Compound 3, a percentage reported as activity, at one concentration (the size of the read-out at that concentration, not a potency): -76%
Estimate against measurement, compound 3: 38 percentage points above; the measured number lies below the stated range.
By their numbers in this assay, from the lowest: compound 3; then compound 1; then compound 2.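

In this assay, the change from hydroxy to methoxy on the 3-chloro-5-hydroxyphenyl group gives a number 31 percentage points lower from compound 1 to compound 3 (beyond the scatter), so this position responds strongly to methyl on the oxygen. The hydrogen on that oxygen is thus not needed for the effect at the one concentration tested, and its replacement moves the number towards the stronger side. Nothing measured on these compounds accounts for the step.

Going by these compounds, whether a longer chain on the oxygen, such as ethoxy, extends the step remains open. So does the outcome with an amine in place of the hydroxy.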